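Fluoro in Place of Hydrogen on Compound 3

This account rests on a few compounds, and the source may have more. Where it says the series, first, only, none or still open, it means among the compounds named here.

Three compounds with a shared core have numbers in a functional assay on U-87MG ATCC cells (Homo sapiens) for cytotoxicity, read by MTT assay, with a stated time of 48 h; on this read-out higher numbers stand for weaker inhibition and lower numbers for stronger inhibition. Compound 1 `CC(=NNC(=S)Nc1cccc([N+](=O)[O-])c1)c1ccccn1` gives 69 nM, compound 2 `CC(=NNC(=S)Nc1cccc(F)c1)c1ccccn1` gives 18 nM, and compound 3 `CC(=NNC(=S)Nc1ccccc1)c1ccccn1` gives 1.4 nM. Compound 3 holds the lowest number of the three, and its steps to both others lie beyond the scatter.

Compound 4 `CC(=NNC(=S)Nc1ccc(F)cc1)c1ccccn1` differs from compound 3 by one change: fluoro in place of hydrogen on an aromatic carbon. This is fluoro in place of hydrogen on an aromatic carbon, para to a large group.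

The closest evidence is the large step of a 13-fold lower number from compound 2 to compound 3 (1.11 log units; beyond the scatter), where hydrogen replaces fluoro. The large step of a 49-fold lower number from compound 1 to compound 3 (1.69 log units; beyond the scatter) and the modest step of a 3.8-fold lower number from compound 1 to compound 2 (0.58 log units; beyond the scatter) also show the unsubstituted compound 3 ahead of both substituted compounds. The data do not show fluoro at the place it takes in compound 4, so the size of the step from compound 2 carries over only loosely. A step to a higher number in this assay is therefore expected, though a smaller one, estimated as a 4.3-fold higher number from compound 3 to compound 4 (0.63 log units; beyond the scatter). The estimate for compound 4 is 6 nM, with an expected range of 1.5 nM to 25 nM.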

Compound 4, half-maximal inhibitory concentration: 10 nM
Compound 4: the middle estimate sits 1.7-fold (0.22 log units) below what was measured, and the stated range covers the measured number.
By their numbers in this assay, from the lowest: compound 3; then compounds 4 and 2 (each within the scatter of the next); then compound 1.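

Fluoro in place of hydrogen, para to a large group, can now be read directly against the unsubstituted compound 3 in this assay, and the change gives a 7.1-fold higher number from compound 3 to compound 4 (0.85 log units; beyond the scatter). The unsubstituted compound therefore keeps its lead over a substituent at this place too, and not only over the fluoro and nitro of compound 2 and compound 1. Compound 4 at 10 nM and compound 2 at 18 nM lie within the scatter of each other, so these values separate the two places of fluoro on the ring no further, and nothing shown here offers an explanation for the step.

Going by these compounds, whether other groups at this place follow fluoro stays open: a chlorine atom, a methoxy group or an amine could go either way. A nitro group at this place is equally untested among the compounds shown.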